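Swapping a sulfonamide for an amide on a shared core

The source may hold more compounds than are shown below. What is called first, only, known or untested is meant among the compounds shown, and "the series" means these compounds.

Compound 3 `O=S(=O)(NCCNc1nccc(-c2c(-c3cccc(F)c3)nc3sccn23)n1)c1cccc(F)c1` holds the top number of three in a functional assay on A-375 cells (Homo sapiens) for cytotoxicity, read by MTT assay (a lower number here means a stronger inhibitor, a higher number a weaker inhibitor), where compound 3 gives 14900 nM. Compound 1 `O=S(=O)(NCCCNc1nccc(-c2c(-c3cccc(F)c3)nc3sccn23)n1)c1cccc(F)c1` gives 13700 nM and compound 2 `O=S(=O)(NCCNc1nccc(-c2c(-c3cccc(F)c3)nc3sccn23)n1)c1ccc(Br)cc1` gives 13500 nM, so the three lie together: a 1.1-fold higher number from compound 1 to compound 3 (0.04 log units; within the scatter), a 1.1-fold higher number from compound 2 to compound 3 (0.04 log units; within the scatter) and a 1.0-fold lower number from compound 1 to compound 2 (0.01 log units; within the scatter). Compound 4 `Cc1ccc(C(=O)NCCNc2nccc(-c3c(-c4cccc(F)c4)nc4sccn34)n2)cc1` differs from compound 3 by (4-methylphenyl)carbonyl in place of (3-fluorophenyl)sulfonyl on an amine nitrogen. Among the compounds with values here, none of the measured steps touches the sulfonyl itself; they change the chain or the ring on the sulfonyl sulfur, and each stayed within the scatter. Within the data shown here, with no directly comparable step on hand, the expected step is a 1.1-fold lower number from compound 3 to compound 4 (0.03 log units; within the scatter), meaning no shift beyond the scatter, though with wide uncertainty. Compound 4 is estimated at 14000 nM, within a range from 4500 nM to 45000 nM.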

Compound 4, half-maximal inhibitory concentration: 5880 nM
Compound 4: middle estimate off by 2.4-fold (0.38 log units), on the high side, within the range that was stated.
By their numbers in this assay, from the lowest: compound 4; then compounds 2, 1 and 3 (each within the scatter of the next).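

In this assay the earlier changes to the chain or to the ring on the sulfonyl stayed within the scatter, but replacing the sulfonyl group with a carbonyl group gives the first shifts beyond it: a 2.5-fold lower number from compound 3 to compound 4 (0.40 log units; beyond the scatter) and a 2.3-fold lower number from compound 2 to compound 4 (0.36 log units; beyond the scatter) and a 2.3-fold lower number from compound 1 to compound 4 (0.37 log units; beyond the scatter) are all modest and all run the same way. So the group on this amine nitrogen can move the number. No evidence shown accounts for this shift.

Going by these compounds, the carbonyl and the 4-methylphenyl ring enter together, so the share of each stays open. Also open, on these data alone, is how a methoxy group on that ring, or a longer chain, would behave alongside the carbonyl.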